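From Pyridin-4-yl to 1H-Indol-7-yl on the Shared Core

The source may report more compounds than this note shows. Statements on the series, on what has been measured and on what is new or still open speak of the compounds shown alone.

In a functional assay on HepG2 cells (Homo sapiens) for cytotoxicity, read by spectrophotometry, with a stated time of 72 h (on this read-out lower numbers stand for stronger inhibition and higher numbers for weaker inhibition), compound 3 `COc1cc(-n2c(-c3ccncc3)cccc2=O)cc(OC)c1OC` gives 1780 nM, the higher of the two numbers available. Compound 2 `COc1cc(-n2c(-c3cccc(F)c3)cccc2=O)cc(OC)c1OC` gives 159 nM. Compound 1 `COc1ccc(-c2cccc(=O)n2-c2cc(OC)c(OC)c(OC)c2)cc1` gives < 10 nM, which is a limit of the assay and not a number.

The next change leads to compound 4 `COc1cc(-n2c(-c3cccc4cc[nH]c34)cccc2=O)cc(OC)c1OC`: 1H-indol-7-yl in place of pyridin-4-yl on an aromatic carbon, next to the ring nitrogen (1H-indol-7-yl in place of pyridin-4-yl on an aromatic carbon).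

Among the measured compounds shown here, three measured steps bear on this position, and all are large. They are an at least 15-fold higher number from compound 1 to compound 2 (1.20 log units; beyond the scatter), an at least 170-fold higher number from compound 1 to compound 3 (2.25 log units; beyond the scatter) and an 11-fold higher number from compound 2 to compound 3 (1.05 log units; beyond the scatter). Both steps that introduce pyridin-4-yl raise the number, so removing that group is expected to lower it in this assay. For the measured compounds named here, no measured compound carries 1H-indol-7-yl, which leaves the size of the step uncertain, and a large step is expected. The expected step is an 8.9-fold lower number from compound 3 to compound 4 (0.95 log units; beyond the scatter). For compound 4, the estimated value is 200 nM, with an expected range of 25 nM to 1500 nM.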

Compound 4, half-maximal inhibitory concentration: 2400 nM
The estimate for compound 4 lay 12-fold (1.08 log units) below the measured number, outside the stated range (above it).
By their numbers in this assay, from the lowest: compound 2; then compounds 3 and 4 (each within the scatter of the next). At a limit, below all of these: compound 1.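

In this assay, the change from pyridin-4-yl to 1H-indol-7-yl gives a 1.3-fold higher number from compound 3 to compound 4 (0.13 log units; within the scatter), so this position accepts either group with no change that can be told from the scatter. Taking pyridin-4-yl away is therefore not enough in itself to lower the number, and a six-membered aromatic ring of carbon only, present in 1H-indol-7-yl, does not suffice either. The gap to the phenyl compounds remains large, with a 15-fold higher number from compound 2 to compound 4 (1.18 log units; beyond the scatter) and an at least 240-fold higher number from compound 1 to compound 4 (2.38 log units; beyond the scatter).

The compounds shown leave open whether a 4-hydroxyphenyl or 4-aminophenyl group at this position would behave like 4-methoxyphenyl. The full size of the gap to compound 1 also stays open because its value is a limit of the assay and not a number: the limit of < 10 nM in this assay, at which 1 of the 4 values shown sits.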